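Cyclopropyl in place of butyl on a triple-bonded carbon

A few compounds are considered here, and "the series" means these few. Any claim that something is new, unique, unknown or untested is made for them only; others in the source may bear on it.

In a functional assay on CAPAN-1 cells (Homo sapiens) for antiproliferative activity, with a stated time of 72 h (on this read-out higher numbers stand for weaker inhibition and lower numbers for stronger inhibition), compound 1 (`CCCC#Cc1cc([C@@H]2O[C@H](CO)[C@@H](O)[C@H]2O)n2ncnc(N)c12`) gives 20 nM and compound 2 (`CCCCC#Cc1cc([C@@H]2O[C@H](CO)[C@@H](O)[C@H]2O)n2ncnc(N)c12`) gives 1000 nM as the higher of the two numbers. Compound 3 (`Nc1ncnn2c([C@@H]3O[C@H](CO)[C@@H](O)[C@H]3O)cc(C#CC3CC3)c12`) has cyclopropyl in place of butyl on a triple-bonded carbon. Going by the values given here, no compound with a ring in this place has been measured. Among the compounds with values here, the only bearing step is the large 50-fold higher number from compound 1 to compound 2 (1.70 log units; beyond the scatter) for methyl in place of hydrogen on a saturated chain carbon, so it is a loose guide. A large move towards stronger inhibition is expected, an estimated 17-fold lower number from compound 2 to compound 3 (1.22 log units; beyond the scatter) overall. Compound 3 is estimated at 60 nM (range 10 nM to 400 nM).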

Compound 3, half-maximal inhibitory concentration: 20 nM
Compound 3: middle estimate off by 3.0-fold (0.48 log units), on the high side, within the range that was stated.
By their numbers in this assay, from the lowest: compounds 1 and 3 (each within the scatter of the next); then compound 2.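

In this assay, cyclopropyl in place of butyl on the triple-bonded carbon restores the lower number (a 50-fold lower number from compound 2 to compound 3 (1.70 log units; beyond the scatter)), so this position accepts a three-membered ring where the longer butyl-bearing chain of compound 2 falls away. Set against the propyl of compound 1, the ring makes no difference beyond the scatter (no change at the digits printed from compound 1 to compound 3 (within the scatter)). No measurement shown accounts for either step. From the compounds shown here alone, whether larger rings such as cyclopentyl or phenyl would match cyclopropyl remains open. So does whether a chain ending in an amine or a hydroxyl would be accepted here.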